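Fluoro in place of tert-butyl: notes on compound 4

This account rests on a few compounds, and the source may have more. Where it says the series, first, only, none or still open, it means among the compounds named here.

Values in a functional assay on KB cells (Homo sapiens) for inhibition; on this read-out higher numbers stand for weaker inhibition and lower numbers for stronger inhibition:
- compound 1 `Nc1nc2cc(Cl)c(Cl)cc2n1Cc1ccccc1`: 170000 nM
- compound 2 `Cc1ccc(Cn2c(N)nc3cc(Cl)c(Cl)cc32)cc1`: 50000 nM
- compound 3 `CC(C)(C)c1ccc(Cn2c(N)nc3cc(Cl)c(Cl)cc32)cc1`: 50000 nM

Compound 3 stands at 50000 nM, level with compound 2 and sharing the lowest of the three numbers. Compound 4 `Nc1nc2cc(Cl)c(Cl)cc2n1Cc1ccc(F)cc1` carries fluoro in place of tert-butyl on an aromatic carbon. Within the data shown here, three measured steps bear on this change. Methyl in place of hydrogen gave a 3.4-fold lower number from compound 1 to compound 2 (0.53 log units; beyond the scatter) and tert-butyl in place of hydrogen gave a 3.4-fold lower number from compound 1 to compound 3 (0.53 log units; beyond the scatter), both modest. Tert-butyl in place of methyl gave no change at the digits printed from compound 2 to compound 3 (within the scatter). Among the measured compounds shown here, no fluoro compound has been measured, so a modest upward step in this assay is expected, landing between the existing values. The expected step runs a 1.8-fold higher number from compound 3 to compound 4 (0.26 log units; within the scatter). Compound 4 is estimated at 90000 nM, with an expected range of 40000 nM to 190000 nM.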

Compound 4, half-maximal inhibitory concentration: 70000 nM
Compound 4: the middle estimate sits 1.3-fold (0.11 log units) above what was measured; the range from low to high includes it.
By their numbers in this assay, from the lowest: compounds 2, 3 and 4 (each within the scatter of the next); then compound 1.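

In this assay, fluoro on this aromatic carbon cannot be told apart from the larger groups (a 1.4-fold higher number from compound 3 to compound 4 (0.15 log units; within the scatter); a 1.4-fold higher number from compound 2 to compound 4 (0.15 log units; within the scatter)). Against hydrogen, it still gives a step beyond the scatter (a 2.4-fold lower number from compound 1 to compound 4 (0.39 log units; beyond the scatter)), so fluoro, methyl and tert-butyl all sit apart from hydrogen but not from one another, whether the group has 1 heavy atom or 4. No supporting data bear on what lies behind this result.

The compounds shown leave open whether an amine or a carboxylic acid at this place would fall with these three groups or move the number beyond the scatter.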